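From methyl to pyridin-2-yl on a carbonyl carbon

The source may report more compounds than this note shows. Statements on the series, on what has been measured and on what is new or still open speak of the compounds shown alone.

Of the compounds shown here, three have been measured in a physicochemical assay for solubility, measured as kinetic solubility, with a stated time of 1 h, at pH 7.4 (a higher number here means a more soluble compound, a lower number a less soluble compound), so far. Compound 1 `O=C(Nc1nc(-c2ccc(Cl)c(Cl)c2)cs1)c1cncs1` gives 2000 nM in this test. Compound 2 `N#CCC(=O)Nc1cccc(-c2ccc(Cl)c(Cl)c2)n1` gives 1000 nM here. Compound 3 `CC(=O)NC1=NN(c2ccc(Cl)c(Cl)c2)CC1` reaches 31000 nM and holds the highest of the three numbers, beyond the scatter from both others.

Compound 4 `O=C(NC1=NN(c2ccc(Cl)c(Cl)c2)CC1)c1ccccn1` has pyridin-2-yl in place of methyl on a carbonyl carbon of compound 3 (pyridin-2-yl in place of methyl on a carbonyl carbon). Within the data shown here, no measured pair shows this change on its own, and the cores of compound 1 and compound 2 differ from that of compound 3, so the comparison is loose. Still, compound 1 carries a ring on its carbonyl and stands at 2000 nM in this assay, so a fall beyond the scatter is expected. The estimated step is a 7.8-fold lower number from compound 3 to compound 4 (0.89 log units; beyond the scatter) and it points downward. For compound 4 the expected value is 4000 nM with an estimated range of 1200 nM to 13000 nM in this assay, and the measurement will settle it.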

Compound 4, solubility: 11000 nM
Compound 4: middle estimate off by 2.8-fold (0.44 log units), on the low side; the measured number falls inside the stated range.
By their numbers in this assay, from the lowest: compounds 2 and 1 (each within the scatter of the next); then compound 4; then compound 3.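

Among these compounds, compound 3 and compound 4 form the first pair here that differs in one place, so they give the first direct reading at this carbonyl carbon. In this assay, pyridin-2-yl in place of methyl gives a 2.8-fold lower number from compound 3 to compound 4 (0.45 log units; beyond the scatter) on the shared core. The step is modest, though methyl gives way to a whole six-membered aromatic ring on a carbonyl carbon whose other neighbour is an amide-type nitrogen. Nothing at hand bears on why the step has this size. As far as these compounds go, the reading rests on this single pair, and it remains open whether the ring nitrogen of pyridin-2-yl plays any part, as phenyl does not appear at this position. Also open, from the compounds shown here alone, is how a chain carrying an amine or a carboxylic acid would compare with methyl and pyridin-2-yl on this carbonyl carbon.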